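Extending the chain from compound 1 to compound 4

A few compounds are considered here, and "the series" means these few. Any claim that something is new, unique, unknown or untested is made for them only; others in the source may bear on it.

Measured in a functional assay on EC9706 cells (Homo sapiens) for antiproliferative activity, read by MTT assay, with a stated time of 48 h; a higher number here means a weaker inhibitor, a lower number a stronger inhibitor:
- compound 1 `CCCCCCCCn1cc(COC[C@@H]2OC[C@H](N)[C@@H]2O)nn1`: 44300 nM
- compound 2 `CCCCCCCCCn1cc(COC[C@@H]2OC[C@H](N)[C@@H]2O)nn1`: 20100 nM
- compound 3 `CCCCCCCCCCCCCCCCn1cc(COC[C@@H]2OC[C@H](N)[C@@H]2O)nn1`: 20000 nM

Compound 1 stands highest of the three, making it the weakest inhibitor measured so far. Compound 4 `CCCCCCCCCCCCCCCCCCn1cc(COC[C@@H]2OC[C@H](N)[C@@H]2O)nn1` is still unmeasured. Its difference from compound 1 is decyl in place of hydrogen on a saturated chain carbon, eight bonds along the chain from an aromatic nitrogen.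

Among the compounds with values here, three measured steps bear on this change. Methyl in place of hydrogen at the same place gives a 2.2-fold lower number from compound 1 to compound 2 (0.34 log units; beyond the scatter), a modest step. Octyl in place of hydrogen there gives a 2.2-fold lower number from compound 1 to compound 3 (0.35 log units; beyond the scatter), also modest and the closest measured parallel to the decyl change. The further step, a 1.0-fold lower number from compound 2 to compound 3 (0.00 log units; within the scatter), lies within the scatter, so the long extension beyond compound 2 shows no additional shift in this assay. Within the data shown here, no measurement yet covers a chain longer than that of compound 3.

A modest step towards a lower number is therefore expected, of about the size seen for compound 3 at 20000 nM. The estimate corresponds to an expected 2.2-fold lower number from compound 1 to compound 4 (0.35 log units; beyond the scatter). For compound 4 the estimated value is 20000 nM, with an expected range of 9000 nM to 45000 nM.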

Compound 4, half-maximal inhibitory concentration: 17800 nM
For compound 4 the middle estimate is 1.1-fold (0.05 log units) above the measured one; the range from low to high includes it.
By their numbers in this assay, from the lowest: compounds 4, 3 and 2 (each within the scatter of the next); then compound 1.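

Extending the chain at this position, on a saturated chain carbon eight bonds along the chain from an aromatic nitrogen, still moves the number in this assay by only a modest amount with decyl in place of hydrogen, a 2.5-fold lower number from compound 1 to compound 4 (0.40 log units; beyond the scatter) and no more than the shorter extensions did. Beyond the chain of compound 3 the numbers stay level, a 1.1-fold lower number from compound 3 to compound 4 (0.05 log units; within the scatter) and a 1.1-fold lower number from compound 2 to compound 4 (0.05 log units; within the scatter) both being within the scatter, so compounds 2, 3 and 4 form one group that compound 1 alone stands above, and the flat stretch now reaches the longest chain shown. Nothing measured here bears on why the numbers level off once the chain passes that of compound 1.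

The compounds shown leave open whether a chain shorter than that of compound 1 would give a higher number still, which would show how steeply the values rise below this flat stretch. They also leave open whether a terminal amine, a carboxylic acid or a phenyl ring on the chain would move the number out of the range shared by compounds 2, 3 and 4.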